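The compounds below may be only part of what the source reports. "The series", "measured", "known", "first", "only" and "open" are said of these compounds alone.

Working notes on the series.

For the measured compounds named here, compound 1 `O=C(O)c1ccccc1NC(=O)C(C1CCCCC1)n1c(-c2ccc(Cl)cc2)nc2cc(F)c(F)cc21` is the weaker of the two measured members: in an assay on isolated protein for displacement of a labelled ligand from Bile acid receptor (Homo sapiens), read by scintillation proximity assay and radioligand binding (a higher number here means a weaker inhibitor, a lower number a stronger inhibitor), compound 1 gives 320 nM, the highest of the two numbers recorded. Going by the values given here, compound 2 `O=C(O)CCc1ccc(NC(=O)[C@H](C2CCCCC2)n2c(-c3ccc(Cl)cc3)nc3cc(F)c(F)cc32)c(F)c1` carries a different acid-bearing aryl group on the amide nitrogen and in this assay compound 2 gives 13 nM; the gap between these two values lies well beyond the scatter of the method, and no single-point step between them is set out, so the two numbers are simply taken as they stand.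

Compound 3 `O=C(O)c1ccc(NC(=O)C(C2CCCCC2)n2c(-c3ccc(Cl)cc3)nc3cc(F)c(F)cc32)nc1` is the next member to be measured. Relative to compound 1 the change is 5-carboxypyridin-2-yl in place of 2-carboxyphenyl on an amide-type nitrogen. The shared core and the cyclohexyl-bearing side chain are untouched; only the acid-bearing aryl group on the amide nitrogen is exchanged.

Among the compounds with values here, since no measured step covers this exchange, the expectation rests on compound 1 at 320 nM and on the fact that compound 2 shows a lower number is reachable with another acid-bearing aryl group. A moderate drop in the number, beyond the scatter, is expected, with the step of a 2.9-fold lower number from compound 1 to compound 3 (0.46 log units; beyond the scatter). Compound 3 is accordingly estimated at 110 nM, within 30 nM to 400 nM.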

Compound 3, half-maximal inhibitory concentration: 200 nM
Beside the measured number, compound 3's estimate is 1.8-fold (0.26 log units) below it, within the range that was stated.
By their numbers in this assay, from the lowest: compound 2; then compounds 3 and 1 (each within the scatter of the next).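

In this assay, 5-carboxypyridin-2-yl in place of 2-carboxyphenyl on an amide-type nitrogen gives a 1.6-fold lower number from compound 1 to compound 3 (0.20 log units; within the scatter), so this exchange does not separate the two acid-bearing aryl groups. For the compounds shown here, this is the first single-place step, and it shows that a ring with one hetero atom can stand in place of a ring of carbon only at this position without a change in the number beyond the scatter, although the carboxy group is also named at a different ring position in the entering group. No available evidence bears on the reason for this result.

The compounds shown leave open whether the ring nitrogen and the placing of the carboxylic acid would each count on their own, since this one step changes both together and may hide opposing contributions. They also leave open how a tetrazole or a primary amide in place of the carboxylic acid of compound 3 would read in this assay.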